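From Chloro to Bromo: A Small Halogen Swap

The compounds below may be only part of what the source reports. "The series", "measured", "known", "first", "only" and "open" are said of these compounds alone.

Measured compounds in a functional assay on SK-BR-3 cells (Homo sapiens) for inhibition, read by MTT assay, with a stated time of 2 days, tested at 100 uM; on this read-out higher numbers stand for more inhibition of growth at the one concentration tested and lower numbers for less inhibition of growth:
- compound 1, `CNC(=O)c1cc(Oc2ccc3nc(NC(=O)Nc4cc(C(F)(F)F)cc(C(F)(F)F)c4)sc3c2)ccn1`, gives 96.3%
- compound 2, `CNC(=O)c1cc(Oc2ccc3nc(NC(=O)Nc4ccc(Cl)cc4)sc3c2)ccn1`, gives 77.4%

Of the two numbers recorded so far, compound 2 stands lowest. For the measured compounds named here, its only neighbour, compound 1, lies higher by a margin that is beyond the usual scatter of this kind of measurement, so the two compounds are genuinely told apart by this assay. Going by the values given here, no pair of measured compounds differs in just one place, so no single-point step can be read from the measured data alone.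

Compound 3, `CNC(=O)c1cc(Oc2ccc3nc(NC(=O)Nc4ccc(Br)cc4)sc3c2)ccn1`, is the next compound to be tested. It differs from compound 2 in one place only: bromo in place of chloro on an aromatic carbon. The rest of the shared core, the amide and the linking groups are untouched.

Among the compounds with values here, with no measured one-place step available, the expectation rests on the nature of the change. One halogen stands in for another on the same aromatic carbon, and nothing is added or removed in terms of rings, donors, acceptors or charge. Such a swap is expected to move the number little, if at all, with no step beyond the scatter in either direction. Compound 3 is therefore estimated at 80%, within a range from 66% to 92%, which is expected to amount to a step of a number 2.6 percentage points higher from compound 2 to compound 3 (within the scatter).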

Compound 3, percent growth inhibition at one concentration: 69.2%
Compound 3: the middle estimate sits 10.8 percentage points above what was measured; the range from low to high includes it.
By their numbers in this assay, from the lowest: compounds 3 and 2 (each within the scatter of the next); then compound 1.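

Bromo in place of chloro on an aromatic carbon, para to a large group, gives the first one-place step in this series: in this assay, the swap amounts to a number 8.2 percentage points lower from compound 2 to compound 3 (within the scatter). This position can therefore hold either 4-chlorophenyl or 4-bromophenyl without this read-out telling the two compounds apart, at least for this one exchange of halogens at the one concentration tested. Nothing measured here explains this result or says what the two halogens do at this position.

For the compounds shown here, compound 1 differs from compound 2 and compound 3 in more than one place, so no step to it can be read, and the part played by any one of its changes stays unknown. On these data alone, it also remains open how this assay would respond to fluoro, iodo, an amine, a carboxylic acid or a longer chain on the same carbon, since one halogen exchange says little about groups of a different kind.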